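The source may report more compounds than this note shows. Statements on the series, on what has been measured and on what is new or still open speak of the compounds shown alone.

Measured so far:
compound 1, `CC(/C=N/N(C)c1ccc([N+](=O)[O-])cc1)=N\NC(=O)c1ccccc1O`, 31500 nM
compound 2, `COc1cc(C(=O)N/N=C(C)/C=N/Nc2ccc([N+](=O)[O-])cc2)ccc1O`, a limit only, > 100000 nM

Two compounds of the series carry a result in an ADME assay on J774 cells (Mus musculus, strain BALB/c) for cytotoxicity, read by resazurin assay, with a stated time of 72 h; on this read-out higher numbers stand for lower toxicity in this test and lower numbers for higher toxicity in this test. Compound 1 gives 31500 nM. For compound 2 only a limit is known, > 100000 nM, so compound 2 stands at the limit of the assay and no number is available for it (the limit of > 100000 nM in this assay, at which 1 of the 2 values shown sits). Among the compounds with values here, compound 1 and compound 2 differ in more than one place, so no single step can be drawn between them; their two values show only that compound 1 has a number while compound 2 sits at the limit.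

Compound 3, `CC(/C=N/Nc1ccc([N+](=O)[O-])cc1)=N\NC(=O)c1ccccc1Cl`, is not yet measured. It differs from compound 2 in one place: 2-chlorophenyl in place of 4-hydroxy-3-methoxyphenyl on a carbonyl carbon. Within the data shown here, no measured step resembles this change. The step from compound 2 to compound 3 is expected to run toward lower numbers, an at least 2.5-fold lower number from compound 2 to compound 3 (0.39 log units; beyond the scatter), though its size cannot be set against the scatter while the starting point is a limit. For compound 3 in this assay the estimate is 40000 nM, with a range from 12000 nM to 100000 nM, and a limit reading remains possible.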

Compound 3, half-maximal cytotoxic concentration: > 100000 nM
Compound 3: no number, only a limit; the forecaster's own chance of this, stated with the estimate: 35%; middle value at least 2.5-fold (0.39 log units) away from the limit.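

Compound 2 and compound 3 both stand at a limit in this assay and no step can be read between them: the limit of > 100000 nM in this assay, at which 2 of the 3 values shown sit. The compounds shown leave open how far 2-chlorophenyl in place of 4-hydroxy-3-methoxyphenyl on a carbonyl carbon moves the read-out, as neither compound has a number.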